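A few compounds are considered here, and "the series" means these few. Any claim that something is new, unique, unknown or untested is made for them only; others in the source may bear on it.

Measured so far in a functional assay on COLO 205 cells (Homo sapiens) for activation, read by flow cytometry, with a stated time of 24 h, tested at 50 uM; on this read-out lower numbers stand for a weaker effect and higher numbers for a stronger effect at the one concentration tested:
compound 1 `C=C1C(=O)O[C@@H]2CC(C)=C([C@@H](C)CCCOC(C)=O)[C@H](OC(C)=O)[C@H]12` gives 15.4%
compound 2 `C=C1C(=O)O[C@@H]2CC(C)=C([C@@H](C)CCCO)[C@H](O)[C@H]12` gives 15.5%

Compound 2 stands at 15.5% in this assay. Among the measured compounds shown here, the only other number belongs to compound 1, whose 15.4% lies within the scatter of the value of compound 2, so the two cannot be told apart on this read-out, and neither compound can be called the stronger of the pair. For the measured compounds named here, no step between measured compounds is available.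

Compound 3 `C=C1C(=O)O[C@@H]2CC(C)=C([C@@H](C)CCCO)[C@H](OC(=O)C(C)CC)[C@H]12` is the next member. It differs from compound 2 in one place: (sec-butyl)carbonyl in place of hydrogen on an oxygen on a saturated carbon. A (sec-butyl)carbonyl now sits on an oxygen on a saturated carbon, where compound 2 carries a hydrogen.

On the two numbers in hand, compound 1 and compound 2 give the same read-out although they differ at both oxygens, so no step beyond the scatter is expected from this assay for the change to compound 3, in either direction. The expected step of a number 0.5 percentage points higher from compound 2 to compound 3 (within the scatter) is therefore essentially flat. Compound 3 is estimated at 16%, with a range from 6% to 30%.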

Compound 3, a percentage reported as activity, at one concentration (the size of the read-out at that concentration, not a potency): 27.2%
Compound 3: the middle estimate sits 11.2 percentage points below what was measured, within the range that was stated.
By their numbers in this assay, from the lowest: compounds 1 and 2 (each within the scatter of the next); then compound 3.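

In this assay, placing a (sec-butyl)carbonyl on an oxygen on a saturated carbon, which turns hydroxy into ((sec-butyl)carbonyl)oxy, gives a number 11.7 percentage points higher from compound 2 to compound 3 (beyond the scatter). Among the compounds shown here, this is the only single-place step so far, and it shows that the read-out responds to a change at this oxygen, which the two earlier compounds could not show, as they differ in two places. The step is modest and rests on one pair, so it establishes a response to this one group at this one position and no trend; no measurement at hand bears on the reason for it.

On these data alone, whether the step belongs to the (sec-butyl)carbonyl itself or would follow from other groups on this oxygen stays open, for instance a plain acetyl alone, a benzoyl or a longer straight-chain acyl. Also open, as far as these compounds go, is how an ester of this kind would read out on the hydroxy at the end of the side chain, and whether an ether or a carbamate at the ring oxygen would give a comparable number.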